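This account rests on a few compounds, and the source may have more. Where it says the series, first, only, none or still open, it means among the compounds named here.

Working notes on the ester series, read in an ADME assay on HepG2 2.2.15 cells (Homo sapiens) for cytotoxicity; a lower number here means that less compound is tolerated, a higher number that more compound is tolerated. Compound 1 (`COc1cccc(/C=C/C(=O)OCCc2c(-c3ccccc3Cl)c3cc(Cl)ccc3[nH]c2=O)c1`) gives > 1300000 nM, which is a limit of the assay and not a number. Among the measured compounds shown here, compound 2 (`O=C(/C=C/c1cccnc1)OCCc1c(-c2ccccc2Cl)c2cc(Cl)ccc2[nH]c1=O`) gives 39000 nM, the only true number so far. The other reading is the limit of > 1300000 nM in this assay, at which 1 of the 2 values shown sits.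

The next compound is compound 3 (`C/C=C(\C)C(=O)OCCc1c(-c2ccccc2Cl)c2cc(Cl)ccc2[nH]c1=O`). The change from compound 2 is 1-methylprop-1-en-1-yl in place of 2-(pyridin-3-yl)ethenyl on a carbonyl carbon, so the aromatic ring leaves and no ring enters.

For the measured compounds named here, one measured step bears on this, an at least 33-fold lower number from compound 1 to compound 2 (1.52 log units; beyond the scatter). It is large, and it is the step in which pyridin-3-yl stands in place of 3-methoxyphenyl. Compound 3 loses that pyridin-3-yl, so a move to a higher number in this assay is expected. A single step with a different group is weak support, so the expected move is moderate and may not reach the size of that step.

The expected change is a 3.1-fold higher number from compound 2 to compound 3 (0.49 log units; beyond the scatter). For compound 3 the estimate is 120000 nM, with an expected range of 30000 nM to 600000 nM.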

Compound 3, half-maximal cytotoxic concentration: 350000 nM
The estimate for compound 3 lay 2.9-fold (0.46 log units) below the measured number; low and high end bracket the measured number.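

In this assay, taking the aromatic ring off this carbonyl carbon altogether gives a 9.0-fold higher number from compound 2 to compound 3 (0.95 log units; beyond the scatter), so the low number seen with 2-(pyridin-3-yl)ethenyl does not persist once 1-methylprop-1-en-1-yl stands in its place. The ring-free group does not reach the level of the 3-methoxyphenyl ester, with an at least 3.7-fold lower number from compound 1 to compound 3 (0.56 log units; beyond the scatter), and among the three compounds shown the order at this position runs from the 2-(pyridin-3-yl)ethenyl ester through the 1-methylprop-1-en-1-yl ester to the 2-(3-methoxyphenyl)ethenyl ester, all of it beyond the scatter. Compound 1 stands at a limit and not a number, so the upper end of that order has no true value and the size of the last step stays a bound: the limit of > 1300000 nM in this assay, at which 1 of the 3 values shown sits.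

The compounds shown leave open whether the low number of compound 2 belongs to the ring nitrogen of the pyridin-3-yl or to the whole 2-(pyridin-3-yl)ethenyl group, a question that an unsubstituted phenyl on the same ethenyl chain would address. Also open, going by these compounds, is how a saturated butyl chain, or a chain ending in an amine, would read on this carbonyl carbon.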